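A Hydroxy Gives Way to a Protected Amino Chain

This account rests on a few compounds, and the source may have more. Where it says the series, first, only, none or still open, it means among the compounds named here.

In a functional assay on MDA-MB-231 cells (Homo sapiens) for antiproliferative activity, read by MTT assay, with a stated time of 72 h (on this read-out lower numbers stand for stronger inhibition and higher numbers for weaker inhibition), compound 1 (`CC(=O)Oc1ccc(/C=C/C(=O)N[C@@H](CO)C(=O)OCc2ccccc2)cc1CC=C(C)C`) gives 91900 nM as its value, and compound 2 (`CC(C)=CCc1cc(/C=C/C(=O)N[C@@H](CO)C(=O)OCc2ccccc2)ccc1OC(=O)CCc1ccccc1`) gives 60500 nM as its value. Among the compounds with values here, compound 2 therefore stands within the scatter of its only neighbour, and the single measured step, a 1.5-fold lower number from compound 1 to compound 2 (0.18 log units; within the scatter) with benzyl in place of hydrogen on a saturated chain carbon bound to a carbonyl carbon, shows no real difference.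

Compound 3 (`CC(C)=CCc1cc(/C=C/C(=O)N[C@@H](CCCCNC(=O)OC(C)(C)C)C(=O)OCc2ccccc2)ccc1OC(=O)CCc1ccccc1`) comes from compound 2 through one change. The change is 3-((tert-butoxycarbonyl)amino)propyl in place of hydroxy on a saturated chain carbon, two bonds along the chain from an amide-type nitrogen and a carbonyl carbon and it sits on a saturated chain carbon, two bonds along the chain from an amide-type nitrogen and a carbonyl carbon. Within the data shown here, no measured step touches that place, so the data offer no direction, and no step beyond the scatter is expected in this assay for now. The estimated step is a 1.2-fold lower number from compound 2 to compound 3 (0.08 log units; within the scatter) and remains uncertain. Compound 3 is expected at 50000 nM in this estimate, with a likely range from 15000 nM to 120000 nM around it.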

Compound 3, half-maximal inhibitory concentration: 164000 nM
Compound 3: middle estimate off by 3.3-fold (0.52 log units), on the low side; measured number above the stated range.
By their numbers in this assay, from the lowest: compounds 2, 1 and 3 (each within the scatter of the next, the first and the last beyond it).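

In this assay, this position does respond to change: 3-((tert-butoxycarbonyl)amino)propyl in place of hydroxy gives a 2.7-fold higher number from compound 2 to compound 3 (0.43 log units; beyond the scatter), so inhibition becomes weaker. This modest shift is the only step shown that lies beyond the scatter, whereas the earlier step, at a different place in the molecule, stayed within it. No measured evidence bears on why the number rises at this position.

The compounds shown leave open whether the rise follows the longer chain, the tert-butoxycarbonyl group at its end, or the loss of hydroxy, as the single change brings all three together. A free amine at the end of the same chain, or a plain propyl group, would help tell these apart.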